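The source may report more compounds than this note shows. Statements on the series, on what has been measured and on what is new or still open speak of the compounds shown alone.

Going by the values given here, in a functional assay on SW480 cells (Homo sapiens) for antiproliferative activity, read by MTT assay, with a stated time of 48 h (a higher number here means a weaker inhibitor, a lower number a stronger inhibitor), compound 1 `O=c1cc(-n2cc(COc3ccccc3)nn2)c2cc(Br)ccc2o1` gives 4990 nM and holds the lower of the two numbers so far, which makes it the stronger inhibitor of the pair. Compound 2 `O=c1cc(-n2cc(COc3cccnc3)nn2)c2cc(Br)ccc2o1` gives 39800 nM in the same measurement. Compound 3 `O=c1cc(-n2cc(COc3ccc(F)cc3)nn2)c2cc(Br)ccc2o1` is still unmeasured and differs from compound 1 in one place, with fluoro in place of hydrogen on an aromatic carbon as the whole change, namely fluoro in place of hydrogen on an aromatic carbon. Among the compounds with values here, the one measured step at the same phenyl group, an 8.0-fold higher number from compound 1 to compound 2 (0.90 log units; beyond the scatter) for pyridin-3-yl in place of phenyl, shows that this part of the molecule can move the number. That step replaced the ring itself, whereas compound 3 keeps the phenyl, so a smaller step is expected in this assay with no firm direction, quite possibly none beyond the scatter. The estimate is a 1.1-fold lower number from compound 1 to compound 3 (0.04 log units; within the scatter) as the expected step. For compound 3 the expected value is 4500 nM within an estimated range of 1600 nM to 12000 nM for repeated measurements.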

Compound 3, half-maximal inhibitory concentration: 1770 nM
Estimate against measurement, compound 3: 2.5-fold (0.41 log units) above, within the range that was stated.
By their numbers in this assay, from the lowest: compound 3; then compound 1; then compound 2.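

Going by these compounds alone, the earlier compounds showed only that replacing the phenyl ring can weaken compound 1, whereas this result shows that the ring can also give a stronger inhibitor while staying in place. In this assay, a single fluoro on the aromatic carbon para to a large group gives a 2.8-fold lower number from compound 1 to compound 3 (0.45 log units; beyond the scatter), and together with the ring change it opens the widest gap among these compounds, a 22-fold lower number from compound 2 to compound 3 (1.35 log units; beyond the scatter). Nothing available here explains why this one atom moves the number.

Going by these compounds, it remains open whether chloro, methyl or methoxy on the same carbon would give a similar step, or whether fluoro on another carbon of the ring would do the same. Also open, on these data alone, is whether fluoro on the pyridin-3-yl ring of compound 2 would give a stronger inhibitor.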